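This account rests on a few compounds, and the source may have more. Where it says the series, first, only, none or still open, it means among the compounds named here.

Of the compounds shown here, three from this series have been tested in a functional assay on HepG2 cells (Homo sapiens) for cytotoxicity, read by MTT assay, with a stated time of 24 h; on this read-out lower numbers stand for stronger inhibition and higher numbers for weaker inhibition. Compound 2, `Fc1ccc(-c2n[nH]cc2/C=N/n2c(OCc3ccccc3)n[nH]c2=S)cc1`, gives 71 ug/mL. Compound 1, `Cc1ccc(COc2nn(CN(c3ccccc3)c3ccccc3)c(=S)n2/N=C/c2c[nH]nc2-c2ccc(Cl)cc2)cc1`, gives 97 ug/mL, a number within the usual scatter of that of compound 2, so the two cannot be told apart. Compound 3, `CCc1n[nH]cc1/C=N/n1c(OCc2ccc(C)cc2)n[nH]c1=S`, reaches only the limit of the assay, > 100 ug/mL (the limit of > 100 ug/mL in this assay, at which 1 of the 3 values shown sits).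

Compound 4, `Cc1ccccc1COc1n[nH]c(=S)n1/N=C/c1c[nH]nc1-c1ccc(F)cc1`, has not yet been measured. It differs from compound 2 in a single place: methyl in place of hydrogen on an aromatic carbon. Among the measured compounds shown here, nothing among the measured pairs shows what such a methyl does here. The expected step from compound 2 to compound 4 in this assay is therefore small, a 1.0-fold lower number from compound 2 to compound 4 (0.01 log units; within the scatter), with no clear direction beyond the scatter. Compound 4 is expected to give about 70 ug/mL, between 35 ug/mL and 140 ug/mL.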

Compound 4, half-maximal inhibitory concentration: 48 ug/mL
For compound 4 the middle estimate is 1.5-fold (0.16 log units) above the measured one, and the stated range covers the measured number.
By their numbers in this assay, from the lowest: compounds 4, 2 and 1 (each within the scatter of the next, the first and the last beyond it). At a limit, above all of these: compound 3.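

Among the compounds shown here, the first single-place step, phenyl to 2-methylphenyl, gives a 1.5-fold lower number from compound 2 to compound 4 (0.17 log units; within the scatter) in this assay. A methyl can therefore sit on this aromatic carbon, ortho to a large group, without a difference that stands out from the scatter. Nothing measured here gives a reason for this small step.

From the compounds shown here alone, whether a methoxy group, an amine or a longer chain at this carbon would also leave the number within the scatter stays open. So does the effect of a methyl elsewhere on this ring.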